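This account rests on a few compounds, and the source may have more. Where it says the series, first, only, none or still open, it means among the compounds named here.

The measured compounds:
compound 1 `CC(C)=N/N=C1\SCC(=O)N1Cc1ccc(N)cc1` with 1200000 nM
compound 2 `CC(C)=N/N=C1\SCC(=O)N1Cc1cccc([N+](=O)[O-])c1` with 1240000 nM
compound 3 `O=C1CS/C(=N\N=C2CCCC2)N1Cc1ccc(Cl)cc1` with 560000 nM

All three were tested in a physicochemical assay, with a stated time of 90 min; on this read-out higher numbers stand for an effect only at larger amounts of compound and lower numbers for an effect already at smaller amounts. Compound 1 gives 1200000 nM and compound 2 gives 1240000 nM, two numbers that lie within the scatter of each other, so nothing can be said about their order. Compound 3 gives 560000 nM, the lowest of the three numbers; its distance to compound 1 and to compound 2 lies beyond the scatter in both cases, so compound 3 is the one showing an effect at the smallest amount. Among the compounds with values here, no pair of measured compounds differs in only one place, so no single step is available as a guide, and the view of the next compound rests on compound 3 alone.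

Compound 4 `O=C1CS/C(=N\N=C2CCCC2)N1Cc1ccccc1F` is derived from compound 3 by one change: 2-fluorophenyl in place of 4-chlorophenyl on a saturated chain carbon bound to an amide-type nitrogen in a ring. Neither compound 1 nor compound 2 tells how this change acts, since each differs from compound 3 in more than one place. The step is expected to be a 1.4-fold higher number from compound 3 to compound 4 (0.15 log units; within the scatter), small and directed toward a somewhat higher number, with a step within the scatter well possible. Compound 4 is therefore estimated at 800000 nM in this assay, within a range from 350000 nM to 2000000 nM.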

Compound 4, half-maximal effective concentration: 700000 nM
Estimate against measurement, compound 4: 1.1-fold (0.06 log units) above; the measured number falls inside the stated range.
By their numbers in this assay, from the lowest: compounds 3, 4, 1 and 2 (each within the scatter of the next, the first and the last beyond it).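

In this assay, within the data shown here, 2-fluorophenyl in place of 4-chlorophenyl on a saturated chain carbon bound to an amide-type nitrogen in a ring gives a 1.3-fold higher number from compound 3 to compound 4 (0.10 log units; within the scatter), and this is the only step at hand between compounds that differ in one place. It shows that, at this position, this read-out does not separate the two groups, even though they differ both in the halogen and in where it stands on the phenyl ring. No measurement at hand bears on why the step has this size, so no cause can be given for it.

On these data alone, compound 3 and compound 4 change the halogen and its place on the ring in a single step, so it stays open whether either change alone would also remain within the scatter. Also open, as far as these compounds go, is how a carboxylic acid on the phenyl ring, or a longer chain in place of the phenyl ring at this position, would read in this assay.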